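Secondary Amine Replaces Dialkylamino on a Fused Core

The compounds below may be only part of what the source reports. "The series", "measured", "known", "first", "only" and "open" are said of these compounds alone.

Measured compounds:
compound 1, `CCN(CC)c1nc(C)nc2c(-c3cnc(OC)cc3C)c(C)nn12`, 14.5 nM;
compound 2, `CCCCN(CCC)c1nc(C)nc2c(-c3c(C)cc(N(C)C)nc3C)c(C)nn12`, 12.8 nM;
compound 3, `CCCCN(CCC)c1nc(C)nc2c(-c3ccc(OC)nc3C)c(C)nn12`, 2.4 nM.

In an assay on cell membranes for displacement of a labelled ligand from corticotropin-releasing factor receptor 1 (Rattus norvegicus) (on this read-out lower numbers stand for stronger inhibition and higher numbers for weaker inhibition), compound 1 gives 14.5 nM, the highest of the three numbers. Compound 2, with 12.8 nM, sits within the scatter of compound 1, so the two cannot be told apart. Compound 3, with 2.4 nM, lies beyond the scatter below compound 1; as the two differ in several places at once, only their two values are shown, and no single step is recorded.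

Compound 4, `CCC(CC)Nc1nc(C)nc2c(-c3cnc(OC)cc3C)c(C)nn12`, has not yet been measured. It differs from compound 1 in one place: (pentan-3-yl)amino in place of diethylamino on an aromatic carbon. For the measured compounds named here, no measured pair shows this change, so its effect is unknown from the data at hand. The expectation is a step of no more than the usual scatter in this assay, in either direction, giving a 1.0-fold higher number from compound 1 to compound 4 (0.01 log units; within the scatter) from compound 1 to compound 4. Compound 4 is therefore estimated at 15 nM, with a range of 5 nM to 45 nM.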

Compound 4, half-maximal inhibitory concentration: 3 nM
Compound 4: middle estimate off by 5.0-fold (0.70 log units), on the high side, outside the stated range (below it).
By their numbers in this assay, from the lowest: compounds 3 and 4 (each within the scatter of the next); then compounds 2 and 1 (each within the scatter of the next).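

In this assay, the aromatic carbon between two ring nitrogen atoms proves sensitive to the amine it carries: with the rest of the structure unchanged, (pentan-3-yl)amino in place of diethylamino gives a 4.8-fold lower number from compound 1 to compound 4 (0.68 log units; beyond the scatter). For the compounds shown here, this is the first single-place change, and it shows that the dialkylamino arrangement of compound 1 is not needed here, since a secondary amine carrying a hydrogen-bond donor gives the lower number. Nothing measured here explains the size or direction of this step.

As far as these compounds go, it remains open whether the amine hydrogen or the shape of the pentan-3-yl chain accounts for the step, a question that ethyl(propyl)amino or straight-chain pentylamino at this position could separate. Whether the same exchange carries over to the aryl groups of compound 2 and compound 3 is also unresolved.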